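Moving from 3-methoxyphenyl to 4-fluorophenyl on compound 1

The source may report more compounds than this note shows. Statements on the series, on what has been measured and on what is new or still open speak of the compounds shown alone.

In a physicochemical assay for lipophilicity, at pH 7.4 (on this read-out higher numbers stand for higher lipophilicity and lower numbers for lower lipophilicity), compound 1 `CNC(=O)c1cc(C(=O)N[C@H]2[C@@H]3COC[C@@H]32)cc2c1OC[C@H]2c1cccc(OC)c1` gives 3.2. Compound 3 `CCC(=O)N1C[C@@H]2[C@H](C1)[C@H]2NC(=O)c1cc(C(=O)NC)c2c(c1)[C@H](c1ccccc1)CO2` gives 3.4, within the usual scatter of compound 1. Compound 2 `CNC(=O)c1cc(C(=O)NC2CC2)cc2c1OC[C@H]2c1cccc(OC)c1` gives 3.8, which lies beyond the scatter of compound 1.

The step to compound 4 `CNC(=O)c1cc(C(=O)N[C@H]2[C@@H]3COC[C@@H]32)cc2c1OC[C@H]2c1ccc(F)cc1` is 4-fluorophenyl in place of 3-methoxyphenyl on a saturated ring carbon. It places 4-fluorophenyl in place of 3-methoxyphenyl on a saturated ring carbon, two ring bonds from the ring oxygen.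

Among the measured compounds shown here, no measured step covers a change at this carbon. For the measured compounds named here, the one step available, a number 0.60 log units higher from compound 1 to compound 2 (beyond the scatter), is a change on an amide-type nitrogen, so it shows only what a change at another place did. Compound 1 and compound 3 differ in more than one place, so compound 3 with 3.4 gives no clean comparison.

With so little direct evidence, only a small move is expected in this assay, namely a number 0.10 log units higher from compound 1 to compound 4 (within the scatter), which would stay within the scatter. For compound 4 the estimated value is 3.3, with an expected range from 3 to 3.7.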

Compound 4, distribution coefficient: 3.6
Estimate against measurement, compound 4: 0.30 log units below; low and high end bracket the measured number.
By their numbers in this assay, from the lowest: compounds 1, 3, 4 and 2 (each within the scatter of the next, the first and the last beyond it).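

Changing the aryl group on the saturated ring carbon, two ring bonds from the ring oxygen, does register in this assay: 4-fluorophenyl in place of 3-methoxyphenyl gives a number 0.40 log units higher from compound 1 to compound 4 (beyond the scatter). Among the compounds shown here, until now the only readable step was a number 0.60 log units higher from compound 1 to compound 2 (beyond the scatter), a change on an amide-type nitrogen, so compound 1 now has a step beyond the scatter at each of two separate places. Nothing available accounts for the rise seen with this exchange.

On these data alone, the exchange alters both the substituent and its place on the phenyl ring, so it remains open which of the two goes with the higher number; a 3-fluorophenyl or a 4-methoxyphenyl group at this carbon would separate them. As far as these compounds go, it is also open whether 4-fluorophenyl would give a similar step on compound 2, which carries a different group on the amide-type nitrogen.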